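The source may report more compounds than this note shows. Statements on the series, on what has been measured and on what is new or still open speak of the compounds shown alone.

Working notes on the series. The three measured compounds share a core and differ in one group carried on it: compound 1 `O=C(O)c1ccc([C@H]2C[C@](O)(c3ccc(OCc4c(-c5c(Cl)cccc5Cl)noc4C4CC4)cc3Cl)C2)cc1`, compound 2 `CC(C)n1nc(C(=O)O)cc1[C@@H]1C[C@H]1c1ccc(OCc2c(-c3c(Cl)cccc3Cl)noc2C2CC2)cc1Cl` and compound 3 `Cn1nc(C(=O)O)c2ccc([C@H]3C[C@](O)(c4ccc(OCc5c(-c6c(Cl)cccc6Cl)noc5C5CC5)cc4Cl)C3)cc21`. In an assay on isolated protein for agonist activity at Bile acid receptor (Homo sapiens), read by FRET (a lower number here means a smaller maximal response, a higher number a larger maximal response), compound 1 gives 105%, compound 2 gives 101% and compound 3 gives 99%. All three values lie within the usual scatter of one another, so compound 2 cannot be set apart from compound 3 or from compound 1 in this assay; every measured compound reaches roughly the full response of the reference.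

Compound 4 `O=C(O)c1cccc([C@@H]2C[C@H]2c2ccc(OCc3c(-c4c(Cl)cccc4Cl)noc3C3CC3)cc2Cl)c1` is not yet measured. Its change from compound 2 is 3-carboxyphenyl in place of 3-carboxy-1-isopropyl-1H-pyrazol-5-yl on a saturated ring carbon. Among the compounds with values here, no measured pair differs at this place, so the step has to be read from the set as a whole: three different groups at the same place all give full response in this assay, and no step beyond the scatter is expected in either direction. The step of a number 1 percentage points lower from compound 2 to compound 4 (within the scatter) is therefore expected to stay within the scatter. For compound 4 the expected value in this assay is 100%, with a range from 85% to 115%.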

Compound 4, largest response reached (reported as efficacy), in percent of the reference or control that the assay uses: 100%
The estimate for compound 4 equals the measured number at the digits printed, within the range that was stated.
By their numbers in this assay, from the lowest: compounds 3, 4, 2 and 1 (each within the scatter of the next).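

Putting 3-carboxyphenyl in place of 3-carboxy-1-isopropyl-1H-pyrazol-5-yl on a saturated ring carbon gives a number 1 percentage points lower from compound 2 to compound 4 (within the scatter) in this assay. Within the data shown here, this is the first step read directly at this place: a six-membered aromatic ring of carbon only and a five-membered aromatic ring with 2 hetero atoms, each with its carboxy group, cannot be told apart here by the largest response reached. Nothing available bears on why the two groups match.

On these data alone, all four compounds carry a carboxylic acid, so it remains open whether a primary amide or a tetrazole at this place would give a comparable response. Only the largest response reached is shown, so whether these groups differ in the concentration needed to reach it also remains open.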